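Chloro in Place of Methyl on Compound 1

A few compounds are considered here, and "the series" means these few. Any claim that something is new, unique, unknown or untested is made for them only; others in the source may bear on it.

Compound 1 `Cc1ccc(-c2nc(=O)o[nH]2)c(-c2ccc([C@@H](C)N(CC3CC3)c3nc4c(C(=O)O)cccc4o3)cc2)c1` was run in an ADME assay on the whole organism (Macaca fascicularis) for metabolic stability, read by LC-MS, using cassette dosing, at a dose of 1 mg/kg by the oral route (on this read-out lower numbers stand for a shorter-lived compound and higher numbers for a longer-lived compound), and gives 2.8 h, the lowest of the two numbers shown, although the gap to compound 2 `CCCCN(c1nc2c(-c3nccn3C)cccc2o1)[C@H](C)c1ccc(-c2ccccc2-c2nnn[nH]2)cc1`, which gives 3.9 h in this assay, lies within the scatter. Compound 3 `C[C@H](c1ccc(-c2cc(Cl)ccc2-c2nc(=O)o[nH]2)cc1)N(CC1CC1)c1nc2c(C(=O)O)cccc2o1` has not yet been measured. It differs from compound 1 by chloro in place of methyl on an aromatic carbon. Among the compounds with values here, no step between measured compounds is available to guide this change, so nothing beyond the scatter is expected in either direction. Compound 3 is expected at 3 h, between 1.5 h and 6 h. The expected step is a 1.1-fold higher number from compound 1 to compound 3 (0.03 log units; within the scatter).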

Compound 3, half-life: 0.8 h
Beside the measured number, compound 3's estimate is 3.8-fold (0.57 log units) above it; the measured number lies below the stated range.
By their numbers in this assay, from the lowest: compound 3; then compounds 1 and 2 (each within the scatter of the next).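

In this assay, chloro in place of methyl on this aromatic carbon, meta to a large group and para to a group of 6 heavy atoms, gives a 3.5-fold lower number from compound 1 to compound 3 (0.54 log units; beyond the scatter) and so moves the read-out beyond the scatter. Within the data shown here, this is the first sign that the position is sensitive to this exchange of one heavy atom for another. Nothing shown explains the drop. As far as these compounds go, whether fluoro, methoxy or plain hydrogen at this place would read nearer compound 1 or nearer compound 3 remains open.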